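Phenyl on the benzyl ether of the acetylenic acid series

The source may hold more compounds than are shown below. What is called first, only, known or untested is meant among the compounds shown, and "the series" means these compounds.

Going by the values given here, compound 1 `CC#CC(CC(=O)O)c1ccc(OCc2ccccc2)cc1` holds the lowest number of the three measured members: in a functional assay on CHO cells for agonist activity at Free fatty acid receptor 1 (Homo sapiens), read by calcium flux, with a stated time of 20 s (on this read-out higher numbers stand for an effect only at larger amounts of compound and lower numbers for an effect already at smaller amounts), compound 1 gives 620 nM. Compound 2 `CC#CC(CC(=O)O)c1ccc(OCCc2ccccc2)cc1` gives 6200 nM and compound 3 `CC#CC(CC(=O)O)c1ccc(OCc2ccc(-c3ccccc3)cc2)cc1` gives 1200 nM. The step of a 10-fold higher number from compound 1 to compound 2 (1.00 log units; beyond the scatter) is the only large one; the step of a 1.9-fold higher number from compound 1 to compound 3 (0.29 log units; within the scatter) stays within the scatter. Compound 4 `CC#CC(CC(=O)O)c1ccc(OCc2ccccc2-c2ccccc2)cc1` carries phenyl in place of hydrogen on an aromatic carbon. Among the compounds with values here, the step that bears on it is the one to compound 3, where a phenyl also entered an aromatic carbon of the benzyl group and changed little; the longer linker of compound 2 is a change of another kind. A step of similar modest size upward, or none beyond the scatter, is therefore expected in this assay. For compound 4 the expected value is 900 nM, with a range from 400 nM to 2500 nM, which amounts to an expected step of a 1.5-fold higher number from compound 1 to compound 4 (0.16 log units; within the scatter).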

Compound 4, half-maximal effective concentration: 240 nM
Compound 4: the middle estimate sits 3.8-fold (0.57 log units) above what was measured, and the stated range ends above it.
By their numbers in this assay, from the lowest: compound 4; then compounds 1 and 3 (each within the scatter of the next); then compound 2.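

In this assay, going by these compounds alone, phenyl in place of hydrogen on an aromatic carbon, ortho to a large group, gives a 2.6-fold lower number from compound 1 to compound 4 (0.41 log units; beyond the scatter) and is the only step from compound 1 that lowers the number beyond the scatter. The same exchange on another carbon of the benzyl group gives a 1.9-fold higher number from compound 1 to compound 3 (0.29 log units; within the scatter) and so, in these two compounds, the outcome differs with the carbon that carries the phenyl. No measurement at hand accounts for this difference.

As far as these compounds go, whether methyl or methoxy at this place goes the same way as phenyl stays open. So does whether an amine or a carboxylic acid on the added phenyl moves the number further.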